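Replacing a Cyclohexyl Amide with a Methoxybenzyl Amine

The compounds below may be only part of what the source reports. "The series", "measured", "known", "first", "only" and "open" are said of these compounds alone.

Compound 1 `COc1ncc(-c2ccc3ncc(NC(=O)C4CCCCC4)c(OC)c3c2)cc1NS(=O)(=O)c1ccc(F)cc1F` is the weakest of the three measured compounds in a functional assay on PC-3 cells (Homo sapiens) for antiproliferative activity, read by sulforhodamine B assay, with a stated time of 72 h (on this read-out lower numbers stand for stronger inhibition and higher numbers for weaker inhibition), where compound 1 gives 6630 nM. Compound 2 `COc1ncc(-c2ccc3ncc(NC(=O)CN4CCN(C)CC4)c(OC)c3c2)cc1NS(=O)(=O)c1ccc(F)cc1F` gives 1730 nM in this assay, and compound 3 `COc1ncc(-c2ccc3ncc(NCc4ccc(C(F)(F)F)cc4)c(OC)c3c2)cc1NS(=O)(=O)c1ccc(F)cc1F` gives 2880 nM. The two steps from compound 1 are both beyond the scatter: a 3.8-fold lower number from compound 1 to compound 2 (0.58 log units; beyond the scatter) and a 2.3-fold lower number from compound 1 to compound 3 (0.36 log units; beyond the scatter), while compounds 2 and 3 lie within the scatter of each other, a 1.7-fold higher number from compound 2 to compound 3 (0.22 log units; within the scatter).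

Compound 4 `COc1ccc(CNc2cnc3ccc(-c4cnc(OC)c(NS(=O)(=O)c5ccc(F)cc5F)c4)cc3c2OC)cc1` differs from compound 1 in one place: 4-methoxybenzyl in place of cyclohexylcarbonyl on a nitrogen on an aromatic ring. For the measured compounds named here, the closest precedent is the step from compound 1 to compound 3, a 2.3-fold lower number from compound 1 to compound 3 (0.36 log units; beyond the scatter), which likewise exchanges the cyclohexylcarbonyl for a benzyl group on the same nitrogen. Going by the values given here, compound 4 carries a 4-methoxybenzyl instead of a 4-(trifluoromethyl)benzyl, and no measured pair separates those two groups, so the expected step is of similar, modest size in the same direction: a 2.2-fold lower number from compound 1 to compound 4 (0.34 log units; beyond the scatter). Compound 4 is therefore estimated at 3000 nM in this assay, with a range from 1200 nM to 7500 nM.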

Compound 4, half-maximal inhibitory concentration: 4520 nM
The estimate for compound 4 lay 1.5-fold (0.18 log units) below the measured number; the measured number falls inside the stated range.
By their numbers in this assay, from the lowest: compounds 2, 3, 4 and 1 (each within the scatter of the next, the first and the last beyond it).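

In this assay, the 4-methoxybenzyl group on this nitrogen does not separate from the cyclohexylcarbonyl: a 1.5-fold lower number from compound 1 to compound 4 (0.17 log units; within the scatter), whereas the step to 4-(trifluoromethyl)benzyl went beyond the scatter. The two benzyl groups cannot be told apart either: a 1.6-fold higher number from compound 3 to compound 4 (0.20 log units; within the scatter), so the swap of methoxy for trifluoromethyl on the aromatic carbon gives no clear change. Against the ((4-methylpiperazin-1-yl)methyl)carbonyl group, however, the 4-methoxybenzyl group does fall short, with a 2.6-fold higher number from compound 2 to compound 4 (0.42 log units; beyond the scatter), a gap that the 4-(trifluoromethyl)benzyl group does not show.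

Nothing available here accounts for these numbers. Going by these compounds, it remains open how this benzyl series would respond to an amine or a carboxylic acid in place of the methoxy, or to a 4-methylpiperazine placed on the benzyl ring.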